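Isopentyl in place of isopropyl: compound 4

The source may hold more compounds than are shown below. What is called first, only, known or untested is meant among the compounds shown, and "the series" means these compounds.

Within the data shown here, compound 2 `COc1c(C)cnc(CN2CC(=O)N(CC(C)C)c3c(Cl)nc(N)nc32)c1C` gives 20 nM in a functional assay on BT-474 cells (Homo sapiens) for inhibition (a higher number here means a weaker inhibitor, a lower number a stronger inhibitor), and is the lowest of the three numbers measured so far. Among the measured compounds shown here, compound 1 `Cc1cnc(CN2CC(=O)N(CC(C)C)c3c(Cl)nc(N)nc32)c(C)c1Br` gives 130 nM in this assay; the step of a 6.5-fold lower number from compound 1 to compound 2 (0.81 log units; beyond the scatter) is the only single-point step in the set. Compound 3 `COc1c(C)cnc(CN2c3nc(N)nc(Cl)c3NC(=O)[C@H]2C)c1C` gives 410 nM in this assay and differs from compound 2 in more than one place, so its gap to compound 2 cannot be assigned to any one change.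

Compound 4 `COc1c(C)cnc(CN2CC(=O)N(CCCC(C)C)c3c(Cl)nc(N)nc32)c1C` differs from compound 2 by isopentyl in place of isopropyl on a saturated chain carbon bound to an amide-type nitrogen in a ring. For the measured compounds named here, none of the measured steps touches the saturated chain carbon bound to the amide-type nitrogen in a ring; the one step with a known size concerns a methoxy in place of bromo on an aromatic carbon and says nothing about the chain. The expectation for compound 4 therefore rests on the structural change alone: for compound 4 a step of a 2.0-fold higher number from compound 2 to compound 4 (0.30 log units; within the scatter) is expected, most likely none beyond the scatter or a small rise in the number. Compound 4 is estimated at 40 nM, with a range from 12 nM to 130 nM.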

Compound 4, half-maximal inhibitory concentration: 1650 nM
Compound 4: middle estimate off by 41-fold (1.62 log units), on the low side, and the stated range ends below it.
By their numbers in this assay, from the lowest: compound 2; then compound 1; then compound 3; then compound 4.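

The saturated chain carbon bound to an amide-type nitrogen in a ring proves sensitive in this assay: isopentyl in place of isopropyl gives an 83-fold higher number from compound 2 to compound 4 (1.92 log units; beyond the scatter). Among these compounds, this large step is the first reading at this position, and it sets the chain change well apart from the modest step on an aromatic carbon, a 6.5-fold lower number from compound 1 to compound 2 (0.81 log units; beyond the scatter). Nothing available bears on why the longer chain carries this penalty.

A single pair cannot show whether the number climbs gradually with chain length, or whether an ethyl group, a cyclopropylmethyl group or a chain ending in an amine would stay close to compound 2. From the compounds shown here alone, whether the same step would appear with bromo in place of methoxy, as in compound 1, also remains open.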